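The source may hold more compounds than are shown below. What is called first, only, known or untested is meant among the compounds shown, and "the series" means these compounds.

The measured compounds:
Compound 1 `CN(C(=O)NC(=O)c1ccccc1F)c1nc(C(F)(F)F)c(C(=O)N/N=C/c2ccccc2C(F)(F)F)s1` gives 5.39 ug/mL in a functional assay on HepG2 cells (Homo sapiens) for inhibition, read by MTT assay, with a stated time of 72 h; a lower number here means a stronger inhibitor, a higher number a weaker inhibitor.
Compound 2 `CN(C(=O)NC(=O)c1c(F)cccc1F)c1nc(C(F)(F)F)c(C(=O)N/N=C/c2cc(C(F)(F)F)cc(C(F)(F)F)c2)s1` gives 6.28 ug/mL in this assay.
Compound 3 `CN(C(=O)NC(=O)c1ccccc1F)c1nc(C(F)(F)F)c(C(=O)N/N=C/c2cccc(C(F)(F)F)c2)s1` gives 20.3 ug/mL in this assay.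

Compound 2 stands second highest of the three numbers. Its nearest neighbour is compound 1, whose number lies within the scatter of that of compound 2, so no order can be drawn between the two; compound 3 sits beyond the scatter with a higher number. Among the compounds with values here, the only step within the set, a 3.8-fold higher number from compound 1 to compound 3 (0.58 log units; beyond the scatter), concerns the aryl on a carbon with a double bond to nitrogen, not the ring on the carbonyl carbon. Compound 4 `CN(C(=O)NC(=O)c1ccc(F)c(F)c1)c1nc(C(F)(F)F)c(C(=O)N/N=C/c2cc(C(F)(F)F)cc(C(F)(F)F)c2)s1` differs from compound 2 by 3,4-difluorophenyl in place of 2,6-difluorophenyl on a carbonyl carbon. Within the data shown here, no measured pair alters the substitution of this ring, so the step from compound 1 to compound 3 offers only an indirect hint that rearranging substituents on an aryl ring moved the number modestly. Lacking a direct precedent, compound 4 is expected to show a 1.1-fold higher number from compound 2 to compound 4 (0.05 log units; within the scatter), a step within the scatter. The estimate for compound 4 in this assay is 7 ug/mL, with a range from 3 ug/mL to 16 ug/mL.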

Compound 4, half-maximal inhibitory concentration: 5.47 ug/mL
The estimate for compound 4 lay 1.3-fold (0.11 log units) above the measured number; the measured number falls inside the stated range.
By their numbers in this assay, from the lowest: compounds 1, 4 and 2 (each within the scatter of the next); then compound 3.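

In this assay, within the data shown here, 3,4-difluorophenyl in place of 2,6-difluorophenyl on a carbonyl carbon gives a 1.1-fold lower number from compound 2 to compound 4 (0.06 log units; within the scatter), the first direct reading of a change to this ring, and the two fluorine patterns cannot be told apart in this pair. The only other step shown, a 3.8-fold higher number from compound 1 to compound 3 (0.58 log units; beyond the scatter), moves a trifluoromethyl group on the other aryl and lies beyond the scatter, so a rearrangement on one aryl ring need not carry the same weight as one on the other. No measurement shown here offers an explanation for this result.

From the compounds shown here alone, it remains open whether this ring would keep its number with an amine, a carboxylic acid or a methoxy group in place of the fluorines. Going by these compounds, it is also open whether the same fluorine swap would read alike with the 2-(trifluoromethyl)phenyl group in place of the 3,5-bis(trifluoromethyl)phenyl group that compound 2 and compound 4 share.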